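The compounds below may be only part of what the source reports. "The series", "measured", "known", "first", "only" and "open" are said of these compounds alone.

Compound 1 `CC1(C)C/C(=N\OC(=O)c2cccc(NC(=O)c3cccc(F)c3)c2)c2c(-c3cccc(F)c3)noc2C1` gives > 25000 nM in a functional assay on MDA-MB-231 cells (Homo sapiens) for antiproliferative activity, read by MTT assay, with a stated time of 72 h; on this read-out lower numbers stand for stronger inhibition and higher numbers for weaker inhibition.
Compound 2 `CC(C)(C)OC(=O)Nc1cccc(C(=O)Nc2cccc(C(=O)O/N=C3\CCCc4onc(-c5ccc(F)cc5)c43)c2)c1` gives > 25000 nM in this assay.

Both values shown are limits of the assay rather than measured numbers. In this assay compound 1 reaches only a limit, and it is reported as > 25000 nM. In the same assay compound 2 likewise reaches only a limit, which stands as > 25000 nM. The two values therefore share one position: the limit of > 25000 nM in this assay, at which 2 of the 2 values shown sit. Among the measured compounds shown here, no pair of measured compounds differs in a single place, so no measured step is available, and where compound 2 stands is known only as that limit.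

Compound 3 `Nc1cccc(C(=O)Nc2cccc(C(=O)O/N=C3\CCCc4onc(-c5ccc(F)cc5)c43)c2)c1` has not yet been measured. It differs from compound 2 in one place: hydrogen in place of tert-butoxycarbonyl on a nitrogen on an aromatic ring. Without a measured step of this kind to lean on, the size of the expected change in this assay is uncertain, and the step from compound 2 to compound 3 is expected to be about an at least 1.2-fold lower number from compound 2 to compound 3 (0.09 log units; that floor lies within the scatter), with the result likely still at or near the limit. Compound 3 is estimated at 20000 nM, within a range from 3000 nM to 100000 nM.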

Compound 3, half-maximal inhibitory concentration: > 25000 nM
Compound 3 gave a limit, no number; the forecaster's own chance of this, stated with the estimate: 60%; middle value at least 1.2-fold (0.09 log units) away from the limit.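

Compound 2 and compound 3 each reach only a limit in this assay, and the step between them cannot be read. Still open is whether hydrogen in place of tert-butoxycarbonyl on that nitrogen changes the antiproliferative activity at all, and how strongly any of the three compounds acts, with every value at one position: the limit of > 25000 nM in this assay, at which 3 of the 3 values shown sit.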